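The source may hold more compounds than are shown below. What is called first, only, known or untested is meant among the compounds shown, and "the series" means these compounds.

Working notes on the series. The compounds share the core of compound 1 `COc1ccc(-c2cc3ccccc3nc2/C=C/C(=O)c2ccc(O)cc2)cc1` and differ in the group on the carbonyl carbon and in its substituent. Among the compounds with values here, in a functional assay on MCF7 cells (Homo sapiens) for antiproliferative activity, read by XTT assay, with a stated time of 72 h (a higher number here means a weaker inhibitor, a lower number a stronger inhibitor), compound 1 gives 6710 nM, the second highest of the three numbers so far. Compound 2 `COc1ccc(-c2cc3ccccc3nc2/C=C/C(=O)c2c(OC)cccc2OC)cc1` gives 4520 nM in this assay, and compound 3 `COc1ccc(-c2cc3ccccc3nc2/C=C/C(=O)c2ccc(N)cc2)cc1` gives 6920 nM. Within the data shown here, of the steps between them, a 1.5-fold lower number from compound 1 to compound 2 (0.17 log units; within the scatter), a 1.0-fold higher number from compound 1 to compound 3 (0.01 log units; within the scatter) and a 1.5-fold higher number from compound 2 to compound 3 (0.18 log units; within the scatter) all lie within the scatter, so neither a swap of the whole group on the carbonyl carbon nor a change of its substituent has moved this assay so far.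

Compound 4 `COc1ccc(-c2cc3ccccc3nc2/C=C/C(=O)c2ccc(Br)s2)cc1` is next: 5-bromothiophen-2-yl in place of 4-hydroxyphenyl on a carbonyl carbon. The steps that swap the whole group on the carbonyl carbon, a 1.5-fold lower number from compound 1 to compound 2 (0.17 log units; within the scatter) and a 1.5-fold higher number from compound 2 to compound 3 (0.18 log units; within the scatter), bear on this change and both stayed within the scatter. Among the measured compounds shown here, no measured step covers a five-membered aromatic ring with a hetero atom in this place, nor the loss of the single hydrogen-bond donor. The step from compound 1 to compound 4 is therefore expected to be small, a 1.1-fold lower number from compound 1 to compound 4 (0.05 log units; within the scatter), with no direction beyond the scatter. Compound 4 is estimated at 6000 nM in this assay, between 2500 nM and 14000 nM.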

Compound 4, half-maximal inhibitory concentration: 910 nM
For compound 4 the middle estimate is 6.6-fold (0.82 log units) above the measured one; measured number outside the range, below it.
By their numbers in this assay, from the lowest: compound 4; then compounds 2, 1 and 3 (each within the scatter of the next).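

With 5-bromothiophen-2-yl on the carbonyl carbon, this assay shows a 7.4-fold lower number from compound 1 to compound 4 (0.87 log units; beyond the scatter) and a 7.6-fold lower number from compound 3 to compound 4 (0.88 log units; beyond the scatter) and a 5.0-fold lower number from compound 2 to compound 4 (0.70 log units; beyond the scatter) and all three steps lie beyond the scatter, so this position can move the number, which the steps among compounds 1, 2 and 3 did not show. The change from compound 1 to compound 4 replaces the six-membered aromatic ring of carbon only with a five-membered aromatic ring with a hetero atom, and it brings in bromine while losing the hydroxy group, all in one step. Nothing available bears on why the number falls.

The compounds shown leave open whether the ring or the bromine carries the step. An unsubstituted thiophen-2-yl group and a 4-bromophenyl group on the carbonyl carbon would separate the two.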